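Aryl replacements on the core of compound 1: clearance

The compounds below may be only part of what the source reports. "The series", "measured", "known", "first", "only" and "open" are said of these compounds alone.

Compound 1 `Nc1ccc(S(=O)(=O)N2CCN(c3ncc(C(O)(C(F)(F)F)C(F)(F)F)cc3C3CC3)CC2)cn1` is the parent of this set. In an ADME assay (liver) for metabolic stability, with Liver microsome (Rattus norvegicus) as the target, using microsomes and NADPH, with a stated time of 30 min, tested at 1 uM (a higher number here means faster removal of the compound, a lower number slower removal), compound 1 gives 27 mL.min-1.g-1, the lowest of the three numbers, though its distance to the others stays within the scatter. Compound 2 `Cn1cc(-c2cc(C(O)(C(F)(F)F)C(F)(F)F)cnc2N2CCN(S(=O)(=O)c3ccc(N)nc3)CC2)cn1` gives 44 mL.min-1.g-1 and compound 3 `Nc1ccc(S(=O)(=O)N2CCN(c3ncc(C(O)(C(F)(F)F)C(F)(F)F)cc3-c3ccncc3)CC2)cn1` gives 31 mL.min-1.g-1 in this assay. The steps that replace the cyclopropyl of compound 1 by an aromatic ring are both small: a 1.6-fold higher number from compound 1 to compound 2 (0.21 log units; within the scatter) and a 1.1-fold higher number from compound 1 to compound 3 (0.06 log units; within the scatter). Between the two aromatic variants the gap is likewise small: a 1.4-fold lower number from compound 2 to compound 3 (0.15 log units; within the scatter).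

Compound 4 `COc1cncc(-c2cc(C(O)(C(F)(F)F)C(F)(F)F)cnc2N2CCN(S(=O)(=O)c3ccc(N)nc3)CC2)c1` carries the change (5-methoxypyridin-3-yl in place of cyclopropyl on an aromatic carbon). Both measured aryl-for-cyclopropyl steps bear on it, and neither left the scatter, so no step beyond the scatter is expected in this assay for compound 4, with at most a slight lean toward a higher number, as the estimated step of a 1.4-fold higher number from compound 1 to compound 4 (0.15 log units; within the scatter) expresses. Compound 4 is therefore estimated at 38 mL.min-1.g-1, with a range from 20 mL.min-1.g-1 to 75 mL.min-1.g-1.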

Compound 4, intrinsic clearance in microsomes: 58 mL.min-1.g-1
The estimate for compound 4 lay 1.5-fold (0.18 log units) below the measured number; the measured number falls inside the stated range.
By their numbers in this assay, from the lowest: compounds 1, 3, 2 and 4 (each within the scatter of the next, the first and the last beyond it).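

In this assay, 5-methoxypyridin-3-yl is the only one of the three aromatic replacements shown for cyclopropyl at this aromatic carbon whose step leaves the scatter, though only modestly: a 2.1-fold higher number from compound 1 to compound 4 (0.33 log units; beyond the scatter). The aromatic replacements themselves do not separate, with a 1.9-fold higher number from compound 3 to compound 4 (0.27 log units; within the scatter) and a 1.3-fold higher number from compound 2 to compound 4 (0.12 log units; within the scatter), so the data show no clear distinction among them. No measurement at hand accounts for the step from compound 1 to compound 4.

Compound 3 and compound 4 differ in both the methoxy group and the point of attachment of the pyridine ring, so the data do not assign the result to either feature. Also open, going by these compounds, is how an unsubstituted pyridin-3-yl, or an amine such as morpholin-4-yl, at this aromatic carbon would read in this assay.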